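This account rests on a few compounds, and the source may have more. Where it says the series, first, only, none or still open, it means among the compounds named here.

Three esters of the same shared core have been measured in an ADME assay on a cell-free system (plasma, Homo sapiens) for metabolic stability, with Plasma (Rattus norvegicus) as the target, read by HPLC, at pH 7.4; a higher number here means that the compound lasts longer, a lower number that the compound disappears faster. Compound 1 `CC(=O)Oc1ccccc1C(=O)O[C@H]1CO[C@H]2[C@@H]1OC[C@H]2OC(=O)c1cccc(O)c1` gives 0.0183 h. Compound 2 `CC(=O)Oc1ccccc1C(=O)O[C@H]1CO[C@H]2[C@@H]1OC[C@H]2OC(=O)c1ccccc1` gives 0.055 h, and compound 3 `COc1cccc(C(=O)O[C@@H]2CO[C@H]3[C@@H]2OC[C@@H]3OC(=O)c2ccccc2OC(C)=O)c1` gives 0.0525 h. Compound 3 thus stands second highest of the three numbers, with compound 2 sitting within the scatter of it and compound 1 lying beyond the scatter below it; the step of a 2.9-fold higher number from compound 1 to compound 3 (0.46 log units; beyond the scatter) separates them.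

Compound 4 `COc1ccc(C(=O)O[C@@H]2CO[C@H]3[C@@H]2OC[C@@H]3OC(=O)c2ccccc2OC(C)=O)cc1` differs from compound 3 only in where the methoxy group sits on the aromatic ring: 4-methoxyphenyl in place of 3-methoxyphenyl on a carbonyl carbon. Among the compounds with values here, no measured step moves a group from one ring position to another, so the closest guide is the step of a 1.0-fold lower number from compound 2 to compound 3 (0.02 log units; within the scatter), which shows that placing a methoxy group on that ring, compared with a bare hydrogen, left the half-life unchanged within the scatter. Since adding the group did nothing measurable, shifting it is expected to do little as well, and the step of a 1.1-fold lower number from compound 3 to compound 4 (0.02 log units; within the scatter) is estimated to fall within the scatter. Compound 4 is therefore expected to give about 0.05 h, with a likely range from 0.025 h to 0.1 h.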

Compound 4, half-life: 0.0525 h
The estimate for compound 4 lay 1.1-fold (0.02 log units) below the measured number; low and high end bracket the measured number.
By their numbers in this assay, from the lowest: compound 1; then compounds 3, 4 and 2 (each within the scatter of the next).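

Moving the methoxy group in this assay gives no change at the digits printed from compound 3 to compound 4 (within the scatter) and so shows for the first time that, on this carbonyl carbon, 3-methoxyphenyl and 4-methoxyphenyl cannot be told apart. The methoxy group at this new ring position also matches the bare phenyl ring, with a 1.0-fold lower number from compound 2 to compound 4 (0.02 log units; within the scatter) as the step, so the earlier result for compound 3 is not confined to one ring position. The step of a 2.9-fold higher number from compound 1 to compound 4 (0.46 log units; beyond the scatter) is beyond the scatter, which leaves compound 1, with its 3-hydroxyphenyl group, as the only one of the four set apart from the others.

No measurement available here explains why these numbers fall as they do.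

On these data alone, whether the insensitivity to ring position holds for other groups stays open, since only the methoxy group has been seen at two positions, and a carboxylic acid or an amine on the same ring could behave quite differently in this assay as could a longer chain in place of the methyl of the methoxy group.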